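Swapping Chloro for Ethyl on a Benzylsulfanyl Amide

The compounds below may be only part of what the source reports. "The series", "measured", "known", "first", "only" and "open" are said of these compounds alone.

Of the compounds shown here, three sharing an ortho-aminoanilide core have been tested in a functional assay on HCT-116 cells (Homo sapiens) for inhibition, read by CCK-8 assay, with a stated time of 72 h, tested at 2 uM; on this read-out higher numbers stand for more inhibition of growth at the one concentration tested and lower numbers for less inhibition of growth. Compound 1 `Nc1ccccc1NC(=O)/C=C/c1ccc(CSc2ccc(Cl)cc2)cc1` gives 5.62% and stands lowest of the three. Compound 3 `Nc1ccccc1NC(=O)c1ccc(CSc2ccc(Cl)cc2)cc1` gives 17.5%, and compound 2 `CCc1ccc(SCc2ccc(C(=O)Nc3ccccc3N)cc2)cc1` gives 40.7%. Among the measured compounds shown here, the one clean comparison among them is between compound 2 and compound 3, where the only change is chloro in place of ethyl on an aromatic carbon: a number 23.2 percentage points lower from compound 2 to compound 3 (beyond the scatter).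

Compound 4 `CCc1ccc(SCc2ccc(/C=C/C(=O)Nc3ccccc3N)cc2)cc1` has not yet been measured. It differs from compound 1 in exactly this way: ethyl in place of chloro on an aromatic carbon. Put another way, a (4-chlorophenyl)sulfanyl group becomes a (4-ethylphenyl)sulfanyl group, while the rest of compound 1 is kept.

For the measured compounds named here, the step from compound 2 to compound 3 is the only measured step that bears on this change, and it runs in the opposite direction. Reversing it, a gain of similar size is expected, giving a number 22.4 percentage points higher from compound 1 to compound 4 (beyond the scatter) in this assay. Compound 4 is therefore estimated at 28%, within a range of 10% to 46%.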

Compound 4, percent growth inhibition at one concentration: 3.29%
Estimate against measurement, compound 4: 24.7 percentage points above; the whole stated range lies above it.
By their numbers in this assay, from the lowest: compounds 4 and 1 (each within the scatter of the next); then compound 3; then compound 2.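

Ethyl in place of chloro on this core gives a number 2.3 percentage points lower from compound 1 to compound 4 (within the scatter) in this assay, so the two groups cannot be told apart at this position here. The swap therefore does not have one fixed effect: made at the same place, it gives a clear step on one core and no readable step on the other, so its size depends on the rest of the molecule. The two cores respond differently to the same change: the same change on two cores in this assay, a number 23.2 percentage points lower (beyond the scatter) from compound 2 to compound 3 and a number 2.3 percentage points higher (within the scatter) from compound 4 to compound 1, 25.5 percentage points apart, beyond the scatter of two such steps

The compounds shown do not reveal whether another group at this position, such as an amine, a carboxylic acid or a longer chain like butyl, would raise the number on this core. They also leave open whether the two groups would still match at a concentration other than the one tested.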